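The source may hold more compounds than are shown below. What is called first, only, known or untested is meant among the compounds shown, and "the series" means these compounds.

Compounds measured in a functional assay on cells for antagonist activity at C-C chemokine receptor type 1 (Homo sapiens), read by FLIPR and calcium flux; a lower number here means a stronger inhibitor, a higher number a weaker inhibitor:
- compound 1, `Cc1c(C(=O)N[C@@H](C)c2cccc(C(F)(F)F)c2F)cnn1-c1ccc(Cl)cc1`: in this assay compound 1 gives 28 nM
- compound 2, `CC[C@H](NC(=O)c1cnn(-c2ccc(Cl)cc2)c1C)c1cccc(C(F)(F)F)c1F`: in this assay compound 2 gives 13 nM

Compound 2 holds the lower of the two numbers; its nearest neighbour is compound 1, and the step of a 2.2-fold lower number from compound 1 to compound 2 (0.33 log units; beyond the scatter) lies beyond the scatter. That step was a methyl in place of hydrogen on a saturated chain carbon, two bonds along the chain from an amide-type nitrogen and an aromatic carbon, read as methyl to ethyl on the side chain.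

Compound 3, `CCC[C@H](NC(=O)c1cnn(-c2ccc(Cl)cc2)c1C)c1cccc(C(F)(F)F)c1F`, carries the change (methyl in place of hydrogen on a saturated chain carbon, three bonds along the chain from an amide-type nitrogen and an aromatic carbon). It is the same kind of lengthening cut one bond further out, ethyl to propyl. Among the measured compounds shown here, the only step that bears on it is a 2.2-fold lower number from compound 1 to compound 2 (0.33 log units; beyond the scatter), which was modest. A second lengthening of the same chain is expected to return a smaller gain, if any, so the estimated step in this assay is a 1.3-fold lower number from compound 2 to compound 3 (0.11 log units; within the scatter), in the same direction but smaller. For compound 3 the estimate in this assay is therefore 10 nM, with a range from 4 nM to 25 nM.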

Compound 3, half-maximal inhibitory concentration: 10 nM
The estimate for compound 3 equals the measured number at the digits printed, within the range that was stated.
By their numbers in this assay, from the lowest: compounds 3 and 2 (each within the scatter of the next); then compound 1.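

In this assay, the place three bonds along the chain from the amide-type nitrogen and the aromatic carbon now has a reading of its own: ethyl to propyl gives a 1.3-fold lower number from compound 2 to compound 3 (0.11 log units; within the scatter), so the added methyl here cannot be told apart from no change, whereas the methyl to ethyl step one bond closer lay beyond the scatter. Across both lengthenings, the propyl chain still stands clear of the methyl, with a 2.8-fold lower number from compound 1 to compound 3 (0.45 log units; beyond the scatter), so among these three compounds the extra length does not give back what the ethyl chain showed. Nothing measured here accounts for either step.

On these data alone, what happens with a butyl chain, or with a branched isopropyl group at the same carbon, remains open, and these three compounds cannot say whether the numbers would stay level or move again. It is equally open how a chain ending in a hydroxyl group or an amine would read in this assay, since every chain shown is plain alkyl.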